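This account rests on a few compounds, and the source may have more. Where it says the series, first, only, none or still open, it means among the compounds named here.

In a functional assay on MCF7 cells (Homo sapiens) for antiproliferative activity, with a stated time of 5 days (a higher number here means a weaker inhibitor, a lower number a stronger inhibitor), compound 1 (`COc1ccc(-c2[nH]c3ccc(OC)cc3c2C=O)cc1`) gives 180 nM and compound 2 (`COc1ccc(-c2[nH]c3ccc(OC)cc3c2C=C(C#N)C#N)cc1`) gives 340 nM on the same scale. Compound 3 (`COc1ccc(-c2[nH]c3cc(F)ccc3c2C=C(C#N)C#N)cc1`) gives 220 nM in the same test. The number for compound 2 lies within the usual scatter of the other two, so these three compounds cannot be ranked.

Compound 4 (`CCCCCc1ccc2[nH]c(-c3ccc(OC)cc3)c(C=C(C#N)C#N)c2c1`) keeps the rest of compound 2 and makes one change: pentyl in place of methoxy on an aromatic carbon. In short, it has pentyl in place of methoxy on an aromatic carbon. Among the measured compounds shown here, the only measured single-place step, a 1.9-fold higher number from compound 1 to compound 2 (0.28 log units; within the scatter), stays within the scatter, but it concerns a different group, so it says little about this swap. A loose hint comes from compound 3, which lacks that methoxy and still gives 220 nM in this assay, though it also differs in other ways. For the measured compounds named here, no compound here carries a pentyl chain, so the uncertainty is wide and no clear direction can be argued. The expected result is no shift beyond the scatter, an estimated 1.1-fold lower number from compound 2 to compound 4 (0.05 log units; within the scatter) in this test. For compound 4 the estimated value is 300 nM, with an expected range from 80 nM to 1100 nM in this test.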

Compound 4, half-maximal inhibitory concentration: 76 nM
Beside the measured number, compound 4's estimate is 3.9-fold (0.60 log units) above it; the whole stated range lies above it.
By their numbers in this assay, from the lowest: compound 4; then compounds 1, 3 and 2 (each within the scatter of the next).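

In this assay, replacing methoxy with pentyl on this six-membered aromatic ring of the fused system gives a 4.5-fold lower number from compound 2 to compound 4 (0.65 log units; beyond the scatter). This is the first step among these compounds to go beyond the scatter, and it shows that this position responds to what is placed on it and accepts a larger, all-carbon chain in place of a group that holds an oxygen and a hydrogen-bond acceptor, with the number going down rather than up. Nothing available here accounts for the drop in the number.

This single swap changes chain size and removes the oxygen at once, so the compounds shown cannot separate those two changes, and a shorter chain such as propyl, a longer one such as octyl, or a chain ending in an amine or a carboxylic acid could each help to tell them apart. From the compounds shown here alone, it also remains open whether pentyl would give a similar step on the core of compound 1, which carries formyl in place of the 2,2-dicyanoethenyl group.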